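Where Both Measured Neighbours Sit at the Limit

A few compounds are considered here, and "the series" means these few. Any claim that something is new, unique, unknown or untested is made for them only; others in the source may bear on it.

In a functional assay on A549 cells (Homo sapiens) for inhibition, with a stated time of 72 h (a lower number here means a stronger inhibitor, a higher number a weaker inhibitor), compound 1 `CCCC1(c2ccccc2)CC(=O)C(C(CC(=O)c2ccc(-c3ccc(Br)cc3)cc2)c2ccccc2)=C(O)O1` gives only a limit, > 10000 nM. Compound 2 `CCCC1(CCc2ccccc2)CC(=O)C(C2CC(c3ccc(-c4ccc(Br)cc4)cc3)Cc3ccccc32)=C(O)O1` likewise gives only a limit in this assay, > 10000 nM. Among the measured compounds shown here, compound 2 thus stands at the limit of the assay rather than at a number, and both of the values shown so far sit at that same limit (the limit of > 10000 nM in this assay, at which 2 of the 2 values shown sit), so no step between measured compounds can be read from them. Compound 3 `CCCC1(CCc2ccccc2)CC(=O)C(C2CC(c3ccc(OCc4ccc(C(F)(F)F)cc4)cc3)Cc3ccccc32)=C(O)O1` differs from compound 2 in a single place: (4-(trifluoromethyl)benzyl)oxy in place of 4-bromophenyl on an aromatic carbon, in words (4-(trifluoromethyl)benzyl)oxy in place of 4-bromophenyl on an aromatic carbon, para to a large group. For the measured compounds named here, with no measured step available and both measured compounds at the limit, the step from compound 2 to compound 3 in this assay is expected to be none beyond the scatter, with no clear direction. That expectation corresponds to a step of a number no higher from compound 2 to compound 3 (the limit leaves the size open). Compound 3 is therefore estimated at 10000 nM in this assay, within a range from 3000 nM to 30000 nM, and it is expected most likely to return only a limit again.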

Compound 3, half-maximal inhibitory concentration: > 10000 nM
Compound 3 gave a limit, no number; the forecaster's own chance of this, stated with the estimate: 70%; the middle value sits exactly at the limit.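

Compound 2 and compound 3 both return only limits in this assay, so no step can be read between them, and the change from 4-bromophenyl to (4-(trifluoromethyl)benzyl)oxy remains unsized: the limit of > 10000 nM in this assay, at which 3 of the 3 values shown sit.

The compounds shown leave open how strongly any of them inhibits in this assay, and which changes to the shared core would give a measurable value.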